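A few compounds are considered here, and "the series" means these few. Any claim that something is new, unique, unknown or untested is made for them only; others in the source may bear on it.

Working notes on the series. The two measured compounds share a core; compound 1 `CCc1ccc2ncn(-c3ccnc(N)n3)c2c1` carries the plain ethyl-bearing core, while compound 2 `C=Cc1cc(C#Cc2ccc3ncn(-c4ccnc(N)n4)c3c2)ccn1` extends it through a triple bond to a 2-vinylpyridin-4-yl group. In an assay on Sf9 cells for inhibition of mitogen-activated protein kinase kinase kinase 14 variant S549D (Homo sapiens), with a stated time of 30 min, in the presence of a further agent that is not named here (a higher number here means a weaker inhibitor, a lower number a stronger inhibitor), compound 1 gives 79400 nM. In this assay compound 2 gives 20000 nM, the lower of the two numbers, and the gap to compound 1 lies beyond the scatter, so compound 2 is the stronger inhibitor of the pair, though both remain weak.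

Compound 3 `C#Cc1cc(C#Cc2ccc3ncn(-c4ccnc(N)n4)c3c2)ncn1` is not yet measured. Relative to compound 2 it changes in one place: a group of 8 heavy atoms (6 carbon, 2 nitrogen; one six-membered aromatic ring with 2 hetero atoms) in place of a group of 8 heavy atoms (7 carbon, 1 nitrogen; one six-membered aromatic ring with 1 hetero atom), on a triple-bonded carbon. Going by the values given here, no measured pair isolates this kind of exchange, so its effect is unknown from the data at hand. Both groups are of the same size and sit at the same position, so the expectation is for no change beyond the scatter, with the step from compound 2 to compound 3 in this assay estimated as no change at the digits printed from compound 2 to compound 3 (within the scatter). On that basis compound 3 is expected to give about 20000 nM in this assay, with a plausible range from 6000 nM to 60000 nM.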

Compound 3, half-maximal inhibitory concentration: 50100 nM
For compound 3 the middle estimate is 2.5-fold (0.40 log units) below the measured one, within the range that was stated.
By their numbers in this assay, from the lowest: compound 2; then compounds 3 and 1 (each within the scatter of the next).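

In this assay, going by these compounds alone, the exchange on the triple-bonded carbon gives a 2.5-fold higher number from compound 2 to compound 3 (0.40 log units; beyond the scatter), a modest step that is the first reading at this place and shows that the number responds to the group there even when the heavy-atom count stays the same. Since compound 3 differs from compound 2 both in its aromatic ring, with 2 hetero atoms in place of 1, and in having a triple bond outside the ring in place of a double bond, this single step cannot be divided between those two changes. Nothing measured here bears on the origin of the step.

The compounds shown leave open whether the step follows the ring or the unsaturated side group, a question that a vinyl group on the ring of compound 3, or an ethynyl group on the ring of compound 2, would address directly. They also leave open how this position responds to groups of another kind, such as an amine or a carboxylic acid on the same ring, given that compound 2 still stands at 20000 nM.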